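This account rests on a few compounds, and the source may have more. Where it says the series, first, only, none or still open, it means among the compounds named here.

Working notes on the series. The shared core is seen in compound 3 `COc1ccc(C2=NN(C3=NC(=O)/C(=C4\C(=O)Nc5ccc(Br)cc54)S3)C(c3ccc(Cl)cc3)C2)cc1`; the series also holds compound 1 `COc1ccc(C2=NN(C3=NC(=O)/C(=C4\C(=O)Nc5ccc(Cl)cc54)S3)C(c3ccc(OC)cc3)C2)cc1` and compound 2 `COc1ccc(C2=NN(C3=NC(=O)/C(=C4\C(=O)Nc5ccccc54)S3)C(c3ccc(Cl)cc3)C2)cc1`. In a functional assay on cells (Cancer cell lines, Homo sapiens) for cytotoxicity, read by sulforhodamine B assay, with a stated time of 48 h (a higher number here means a weaker inhibitor of growth, a lower number a stronger inhibitor of growth), compound 3 gives 140 nM. Compound 1 gives 190 nM in this assay, a gap to compound 3 that lies within the scatter. Compound 2 gives 100000 nM in this assay, far away from the other two. Going by the values given here, the one measured step in this assay, a 710-fold lower number from compound 2 to compound 3 (2.85 log units; beyond the scatter), shows that a halogen at this place on the fused ring carries the large gain.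

Compound 4 `COc1ccc(C2=NN(C3=NC(=O)/C(=C4\C(=O)Nc5ccc(Cl)cc54)S3)C(c3ccc(Cl)cc3)C2)cc1` is not yet measured in this assay. It differs from compound 3 by chloro in place of bromo on an aromatic carbon. Among the compounds with values here, no measured pair shows a chloro-for-bromo exchange at this place, so the step can only be judged indirectly. Compound 1 carries chloro at the same place on the fused ring and gives 190 nM, close to compound 3 at 140 nM, although compound 1 also carries a different group on the other aryl ring. On that basis the expected step of a 1.2-fold higher number from compound 3 to compound 4 (0.08 log units; within the scatter) from compound 3 to compound 4 is none beyond the scatter. For compound 4 in this assay the estimate is 170 nM, with a range of 70 nM to 400 nM.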

Compound 4, concentration for 50% growth inhibition: 200 nM
For compound 4 the middle estimate is 1.2-fold (0.07 log units) below the measured one, within the range that was stated.
By their numbers in this assay, from the lowest: compounds 3, 1 and 4 (each within the scatter of the next); then compound 2.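

In this assay the direct exchange at this place on the fused ring, a 1.4-fold higher number from compound 3 to compound 4 (0.15 log units; within the scatter) for chloro in place of bromo, stays within the scatter, so these two halogens cannot be told apart here. The large gain over hydrogen is now seen with chloro as well as with bromo, as a 500-fold lower number from compound 2 to compound 4 (2.70 log units; beyond the scatter) shows for chloro in place of hydrogen, so it is not tied to bromo alone, and the step of a 1.1-fold higher number from compound 1 to compound 4 (0.02 log units; within the scatter) gives a clean reading of chloro in place of methoxy on the other aryl ring, with no change beyond the scatter. Nothing measured alongside these numbers bears on the reason for the halogen gain or on what separates these compounds.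

The compounds shown leave open whether the gain belongs to halogens as a class, since fluoro, and non-halogen groups such as methoxy, an amine, a nitrile or a carboxylic acid, do not appear at this place on the fused ring. They also leave open whether the other aryl ring tolerates anything beyond chloro and methoxy, such as a hydroxyl or a longer alkoxy chain.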